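The source may hold more compounds than are shown below. What is called first, only, known or untested is meant among the compounds shown, and "the series" means these compounds.

Working notes on the series. Compound 1 `CCCCN(CC)c1nc(C)nc2c(-c3ccc(OC)cc3C)c(C)nn12` gives 2.3 nM in an assay on cell membranes for displacement of a labelled ligand from corticotropin-releasing factor receptor 1 (Rattus norvegicus); on this read-out lower numbers stand for stronger inhibition and higher numbers for weaker inhibition. Compound 2 `COc1cc(C)c(-c2c(C)nn3c(NC4CCC4)nc(C)nc23)c(OC)c1` gives 17.4 nM, and compound 3 `COc1ccc(-c2c(C)nn3c(NC4CCC4)nc(C)nc23)c(C)c1` gives 24.6 nM. On these three numbers compound 2 sits second highest, with compound 3 nearest to it and compound 1 furthest away: the step of a 1.4-fold higher number from compound 2 to compound 3 (0.15 log units; within the scatter) stays within the scatter, whereas the gap to compound 1 lies well beyond it.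

Compound 4 `CCC(CC)Nc1nc(C)nc2c(-c3c(C)cc(OC)cc3OC)c(C)nn12` is not yet measured. It differs from compound 2 in one place: pentan-3-yl in place of cyclobutyl on a nitrogen on an aromatic ring. The measured step that bears on this is an 11-fold higher number from compound 1 to compound 3 (1.03 log units; beyond the scatter), where cyclobutylamino in place of butyl(ethyl)amino on the shared core weakened binding considerably. Within the data shown here, that step runs in the opposite sense to the present change, in which the cyclobutyl leaves and an open pentan-3-yl enters on the same nitrogen; no measured pair shows the pentan-3-yl group itself, so the size is uncertain. The expectation is therefore a lower number for compound 4 than for compound 2, with the step of a 3.5-fold lower number from compound 2 to compound 4 (0.54 log units; beyond the scatter) expected to fall beyond the scatter but short of the full swing seen in the other direction. Compound 4 is estimated at 5 nM, within 1.5 nM to 16 nM.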

Compound 4, half-maximal inhibitory concentration: 5 nM
The estimate for compound 4 equals the measured number at the digits printed; measured number inside the range.
By their numbers in this assay, from the lowest: compound 1; then compound 4; then compounds 2 and 3 (each within the scatter of the next).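

The step of a 3.5-fold lower number from compound 2 to compound 4 (0.54 log units; beyond the scatter) in this assay shows that this position on the nitrogen still responds with the aryl group of compound 2 in place, whereas the earlier large step on this nitrogen was read with the aryl group shared by compounds 1 and 3. It also shows that binding in this series can shift beyond the scatter while the nitrogen keeps its hydrogen, since compounds 2 and 4 both carry a single carbon substituent there, and that an open pentan-3-yl can stand in place of the four-membered cyclobutyl ring with a lower number as the result. Nothing measured on hand explains why this change lowers the number.

Going by these compounds, what remains open is whether the lower number follows from losing the ring or from the larger carbon count, a question that a cyclopentyl group on the same nitrogen would separate, as it keeps a ring with the carbon count of pentan-3-yl. Also open, on these data alone, is whether the step holds with the aryl group of compound 3, and how a butyl(ethyl)amino group behaves on the aryl group of compound 2.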